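Replacing Thiophen-3-yl with Pyridin-3-yl in Compound 2

This account rests on a few compounds, and the source may have more. Where it says the series, first, only, none or still open, it means among the compounds named here.

Compound 2 `Oc1ccc(-c2cc(-c3ccsc3)cc(-c3ccc(O)cc3)n2)cc1` gives 1040 nM in a functional assay on HCT-15 cells (Homo sapiens) for cytotoxicity, read by CCK-8 assay (a lower number here means a stronger inhibitor, a higher number a weaker inhibitor), the only number shown in this assay. Compound 1 `Oc1ccc(-c2cc(-c3ccsc3)cc(-c3ccccc3O)n2)cc1` gives only > 50000 nM in this assay, a limit rather than a number (the limit of > 50000 nM in this assay, at which 1 of the 2 values shown sits). Among the compounds with values here, the single measured step, an at least 48-fold lower number from compound 1 to compound 2 (1.68 log units; beyond the scatter), changes the hydroxyphenyl and so does not touch the position altered here. Compound 3 `Oc1ccc(-c2cc(-c3cccnc3)cc(-c3ccc(O)cc3)n2)cc1` differs from compound 2 by pyridin-3-yl in place of thiophen-3-yl on an aromatic carbon. Within the data shown here, with no measured step at that position, no change beyond the scatter is expected. Compound 3 is therefore estimated at 1500 nM, ranging from 400 nM to 6000 nM. The expected step is a 1.4-fold higher number from compound 2 to compound 3 (0.16 log units; within the scatter).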

Compound 3, half-maximal inhibitory concentration: 840 nM
For compound 3 the middle estimate is 1.8-fold (0.25 log units) above the measured one; the measured number falls inside the stated range.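

The position opposite the ring nitrogen now has its first measured step: in this assay, the pyridin-3-yl group takes the place of the thiophen-3-yl group with a 1.2-fold lower number from compound 2 to compound 3 (0.09 log units; within the scatter). A five-membered aromatic ring with sulfur and a six-membered aromatic ring with nitrogen therefore cannot be told apart at this position in this assay. Nothing shown here gives a reason for this result.

As far as these compounds go, it remains open whether a carboxylic acid, an amine or a longer alkyl chain at this position would give a similar value. The compounds shown also leave open how a non-aromatic ring such as piperidine would behave there.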